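The source may hold more compounds than are shown below. What is called first, only, known or untested is meant among the compounds shown, and "the series" means these compounds.

Measured so far in an ADME assay on HCT-116 cells (Homo sapiens) for cytotoxicity, read by CellTiter-Glo, with a stated time of 72 h; on this read-out higher numbers stand for weaker inhibition and lower numbers for stronger inhibition:
- compound 1 `CC1CCN(C2CCN(S(=O)(=O)c3cccc(Br)c3)CC2)CC1` gives > 5000 nM
- compound 2 `COc1ccc(OC)c(S(=O)(=O)N2CCC(N3CCC(C)CC3)CC2)c1` gives > 5000 nM

Compound 2 stands at a limit of the assay (> 5000 nM), so its result is not an exact number. The next compound to be tested is compound 3 `COc1ccc(Br)cc1S(=O)(=O)N1CCC(N2CCC(C)CC2)CC1`, which has not yet been measured. It puts bromo in place of methoxy on an aromatic carbon.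

Compound 1, which also carries a bromo group, stands at a limit too (> 5000 nM). No step beyond the usual scatter is therefore expected in this assay, and the expected change is a step that the limit leaves unreadable from compound 2 to compound 3.

Compound 3 is estimated to give 7000 nM, with an expected range from 3000 nM to 20000 nM.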

Compound 3, half-maximal inhibitory concentration: > 5000 nM
Compound 3: only a limit was reported (the forecaster's own chance of this, stated with the estimate: 85%); the middle value lies beyond the limit too.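

No step can be read between compound 3 and either compound 1 or compound 2 in this assay, because all three compounds stand at a limit and not at an exact number: the limit of > 5000 nM in this assay, at which 3 of the 3 values shown sit.

The compounds shown leave open whether bromo in place of methoxy changes the result at all.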